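Methoxy in place of furan-2-yl on the shared core

The compounds below may be only part of what the source reports. "The series", "measured", "known", "first", "only" and "open" are said of these compounds alone.

Of the compounds shown here, two carry numbers so far. In a functional assay on K562-TAX cells (Homo sapiens), read by MTT assay, with a stated time of 3 days (on this read-out lower numbers stand for stronger inhibition and higher numbers for weaker inhibition), compound 1 `Nc1ncnc2[nH]cc(Sc3cccs3)c12` gives 17900 nM. Compound 2 `c1coc(-c2ncnc3[nH]cc(Sc4cccs4)c23)c1` gives 18900 nM, which places compound 2 within the scatter of compound 1. Compound 3 `COc1ncnc2[nH]cc(Sc3cccs3)c12` is still unmeasured and has methoxy in place of furan-2-yl on an aromatic carbon. Going by the values given here, the only measured step at this place is a 1.1-fold higher number from compound 1 to compound 2 (0.02 log units; within the scatter), furan-2-yl in place of amino. Amino and furan-2-yl thus give values that cannot be told apart, though this rests on a single step and methoxy itself is untested. No change beyond the scatter is therefore expected in this assay, and the expected step is a 1.1-fold lower number from compound 2 to compound 3 (0.02 log units; within the scatter). The estimate for compound 3 is 18000 nM, with an expected range from 7000 nM to 45000 nM.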

Compound 3, half-maximal inhibitory concentration: 44000 nM
Compound 3: middle estimate off by 2.4-fold (0.39 log units), on the low side; the range from low to high includes it.
By their numbers in this assay, from the lowest: compounds 1 and 2 (each within the scatter of the next); then compound 3.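

In this assay, going by these compounds alone, methoxy is the first group on this aromatic carbon to stand apart, with a 2.3-fold higher number from compound 2 to compound 3 (0.37 log units; beyond the scatter) and a 2.5-fold higher number from compound 1 to compound 3 (0.39 log units; beyond the scatter) and with both steps modest but beyond the scatter. The position is therefore not indifferent to its substituent, and the three groups do not sort by ring content: amino, without a ring, and furan-2-yl, with one, lie within the scatter of each other, while methoxy, also without a ring, stands apart. Nothing shown bears on why methoxy differs from the other two.

As far as these compounds go, whether a longer alkoxy chain such as ethoxy, a methylamino group or a plain hydrogen on this carbon would sit with methoxy or with amino and furan-2-yl stays open. With only one read-out shown, whether the same gap appears elsewhere also stays open.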